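A methyl-for-chlorine swap on a shared core

A few compounds are considered here, and "the series" means these few. Any claim that something is new, unique, unknown or untested is made for them only; others in the source may bear on it.

Compound 1 `Fc1cccc(-c2nc(Nc3cccc(Cl)c3)c3cc(F)ccc3n2)c1` was tested in a functional assay on MCF7 cells (Homo sapiens) for cytotoxicity, read by MTT assay, with a stated time of 48 h; a higher number here means a weaker inhibitor, a lower number a stronger inhibitor. In this assay compound 1 gives only a limit, > 50000 nM, and no number. Two close relatives stand at the same boundary. Compound 2 `Fc1cccc(-c2nc(Nc3ccccc3Br)c3cc(F)ccc3n2)c1` gives a limit in this assay, > 50000 nM. Compound 3 `Nc1ccccc1Nc1nc(-c2cccc(F)c2)nc2ccc(F)cc12` likewise gives a limit in this assay, > 50000 nM. The steps between these three, a step that the two limits leave unreadable from compound 1 to compound 2, a step that the two limits leave unreadable from compound 1 to compound 3 and a step that the two limits leave unreadable from compound 2 to compound 3, cannot be read in size; each end is a boundary rather than a number, and the limit of > 50000 nM in this assay, at which 3 of the 3 values shown sit, gathers every measured value here.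

Compound 4 `Cc1ccc(Nc2nc(-c3cccc(F)c3)nc3ccc(F)cc23)cc1` differs from compound 1 in one place: 4-methylphenyl in place of 3-chlorophenyl on a nitrogen on an aromatic ring. Going by the values given here, none of the measured steps reveals what this change does to potency; they show only that three different groups on the same nitrogen all leave the compound at the boundary of this assay. The expected step of a number no higher from compound 1 to compound 4 (the limit leaves the size open) is accordingly nothing beyond the usual scatter, with compound 4 most likely remaining at that boundary as well. Compound 4 is estimated at 50000 nM in this assay, within a range from 15000 nM to 150000 nM.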

Compound 4, half-maximal inhibitory concentration: > 50000 nM
Compound 4 gave a limit, no number; the forecaster's own chance of this, stated with the estimate: 80%; the middle value lies on the limit itself.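

In this assay compound 4 gives > 50000 nM, which is a limit and not a number. Its steps to compound 1, compound 2 and compound 3 therefore cannot be read in size, and all four compounds stand at the same boundary: the limit of > 50000 nM in this assay, at which 4 of the 4 values shown sit.

Going by these compounds, whether any of these groups on the nitrogen changes potency at all stays open, with no number here to compare.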